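The compounds below may be only part of what the source reports. "The series", "measured", "known", "first", "only" and "open" are said of these compounds alone.

Measured so far:
compound 1, `NC(=S)N/N=C/c1cc2cccnc2s1`, 6290 nM
compound 2, `Cc1cccc(NC(=S)N/N=C/c2ccc3ccccc3n2)c1`, > 100000 nM
compound 3, `CN(C)C(=S)N/N=C/c1cnc2ccccc2n1`, 750 nM

In a functional assay on HeLa cells (Homo sapiens) for antiproliferative activity, read by sulforhodamine B assay, with a stated time of 72 h (a lower number here means a stronger inhibitor, a higher number a weaker inhibitor), compound 2 gives > 100000 nM, which is a limit of the assay and not a number. This is the limit of > 100000 nM in this assay, at which 1 of the 3 values shown sits. Among the three measured compounds it is therefore the one with no value at all, while compound 1 gives 6290 nM and compound 3 gives 750 nM in this assay. Going by the values given here, no two of the measured compounds differ in one place only, so no measured step connects them.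

Compound 4, `S=C(N/N=C/c1ccc2ccccc2n1)Nc1ccccc1Br`, is not yet measured. It differs from compound 2 by 2-bromophenyl in place of 3-methylphenyl on an amide-type nitrogen. The change keeps the same core and the same amide-type nitrogen; only the aryl group on that nitrogen is exchanged.

Since compound 2 sits at the limit, the step from compound 2 to compound 4 cannot be read off anything measured. The expectation is that compound 4 stays weak, with a step of an at least 1.6-fold lower number from compound 2 to compound 4 (0.22 log units; that floor lies within the scatter) that is expected to be small and may not be resolved at all if compound 4 also reaches the limit. Compound 4 is estimated at 60000 nM, between 10000 nM and 200000 nM.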

Compound 4, half-maximal inhibitory concentration: > 100000 nM
Compound 4: no number, only a limit; the forecaster's own chance of this, stated with the estimate: 50%; middle value at least 1.6-fold (0.22 log units) from the limit.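

Compound 2 and compound 4 both sit at a limit of the assay and not at a number, so no step can be read between them: the limit of > 100000 nM in this assay, at which 2 of the 4 values shown sit.

Left open is whether 2-bromophenyl and 3-methylphenyl on the amide-type nitrogen differ at all, and whether any aryl group at that nitrogen on this core gives a readable number.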